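The compounds below may be only part of what the source reports. "The series", "measured", "known", "first", "only" and "open" are said of these compounds alone.

In an ADME assay on NIH3T3 cells (Mus musculus) for cytotoxicity, read by XTT assay, with a stated time of 24 h (a higher number here means a weaker inhibitor, a lower number a stronger inhibitor), the measured compounds are:

Compound 1 `Cn1nnnc1SCC(=O)N/N=C/c1ccccc1Cl` gives > 10000000 nM, which is a limit of the assay rather than a number.
Compound 2 `Cn1nnnc1SCC(=O)N/N=C/c1cccc(Cl)c1` gives 7500000 nM.
Compound 3 `COc1cccc(/C=N/NC(=O)CSc2nnnn2C)c1` gives 600000 nM.

Within the data shown here, compound 2 has the highest number among the two numbers recorded; its nearest neighbour is compound 3, reached by a 13-fold lower number from compound 2 to compound 3 (1.10 log units; beyond the scatter), and the only other value is a limit (the limit of > 10000000 nM in this assay, at which 1 of the 3 values shown sits). Compound 4 `Cn1nnnc1SCC(=O)N/N=C/c1cccc(Cl)c1Cl` differs from compound 2 by one change: chloro in place of hydrogen on an aromatic carbon. Among the measured compounds shown here, no measured step adds a chloro group, so the one step seen, from a different exchange, offers only a loose guide to the size expected. Compound 4 is estimated at 5000000 nM, between 1000000 nM and 20000000 nM, meaning an expected 1.5-fold lower number from compound 2 to compound 4 (0.18 log units; within the scatter).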

Compound 4, half-maximal inhibitory concentration: 520000 nM
Estimate against measurement, compound 4: 9.6-fold (0.98 log units) above; measured number below the stated range.
By their numbers in this assay, from the lowest: compounds 4 and 3 (each within the scatter of the next); then compound 2. At a limit, above all of these: compound 1.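

In this assay, among these compounds, placing a chloro group on the aromatic carbon ortho to a chloro group gives a 14-fold lower number from compound 2 to compound 4 (1.16 log units; beyond the scatter), the first measured step that adds a group rather than exchanging one. The second chloro group also counts against the other single-chloro compound, with an at least 19-fold lower number from compound 1 to compound 4 (1.28 log units; beyond the scatter), a step that starts from a limit of the assay. Nothing measured here explains this drop. As far as these compounds go, whether an amine or a carboxylic acid at this same place would give a similar step stays open. So does whether any such step would hold without the neighbouring chloro group.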